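Chloro to Trifluoromethyl on a Sulfonyl-Bound Phenyl Ring

This account rests on a few compounds, and the source may have more. Where it says the series, first, only, none or still open, it means among the compounds named here.

Three compounds have been measured in a functional assay on MCF7 cells (Homo sapiens) for antiproliferative activity, read by MTT assay, with a stated time of 72 h; on this read-out higher numbers stand for weaker inhibition and lower numbers for stronger inhibition:
- compound 1, `CCOC(=O)c1oc2ccc(NS(=O)(=O)c3cccc(Cl)c3)cc2c1C`, gives 83900 nM
- compound 2, `CCOC(=O)c1oc2ccc(NS(=O)(=O)c3ccccc3Cl)cc2c1C`, gives > 200000 nM
- compound 3, `CCOC(=O)c1oc2ccc(NS(=O)(=O)c3cccc(C(F)(F)F)c3)cc2c1C`, gives 51400 nM

The value for compound 2 is not a number but a limit of the assay, namely (the limit of > 200000 nM in this assay, at which 1 of the 3 values shown sits).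

Compound 1 and compound 2 are built from the same atoms joined differently: 2-chlorophenyl in place of 3-chlorophenyl on a sulfonyl sulfur. This rearrangement gives an at least 2.3-fold higher number from compound 1 to compound 2 (0.37 log units; beyond the scatter). Compound 3 differs from compound 1 by trifluoromethyl in place of chloro on an aromatic carbon, a change that gives a 1.6-fold lower number from compound 1 to compound 3 (0.21 log units; within the scatter), so on this evidence the two compounds cannot be told apart.

Compound 4, `CCOC(=O)c1oc2ccc(NS(=O)(=O)c3ccccc3C(F)(F)F)cc2c1C`, is not yet measured. It differs from compound 2 by trifluoromethyl in place of chloro on an aromatic carbon. Among the measured compounds shown here, this is the same kind of change as the one from compound 1 to compound 3, but the surroundings are not identical: in compound 3 the entering trifluoromethyl sits meta to a large group, whereas in compound 4 it sits ortho to a large group.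

Because the step of a 1.6-fold lower number from compound 1 to compound 3 (0.21 log units; within the scatter) lay within the scatter, the corresponding step is expected to be small, and the step from compound 2 to compound 4 is estimated as a number no higher from compound 2 to compound 4 (the limit leaves the size open). Since compound 2 reached only a limit, compound 4 is expected to do much the same, and the estimate for compound 4 is 200000 nM, with a range from 80000 nM to 500000 nM.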

Compound 4, half-maximal inhibitory concentration: 93900 nM
For compound 4 the middle estimate is 2.1-fold (0.33 log units) above the measured one, and the stated range covers the measured number.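

In this assay, trifluoromethyl in place of chloro on an aromatic carbon, ortho to a large group, gives an at least 2.1-fold lower number from compound 2 to compound 4 (0.32 log units; beyond the scatter). Compound 2 has no exact number to anchor this step, only a limit of the assay: the limit of > 200000 nM in this assay, at which 1 of the 4 values shown sits. Seen across both cores, the change does not raise the number on either one, but this does not show that it carries over from one core to the other with the same size: the same change on two cores in this assay, a 1.6-fold lower number (0.21 log units; within the scatter) from compound 1 to compound 3 and an at least 2.1-fold lower number (0.32 log units; beyond the scatter) from compound 2 to compound 4; the limit leaves it open whether they differ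

The compounds shown compare only chloro and trifluoromethyl on the sulfonyl-bound phenyl ring, which leaves open how a smaller or differently built group, such as a nitrile, a methoxy group or an amine, would behave there. On these data alone, it also remains open whether the same change would give a similar result if the ethyl ester on the shared core were replaced by a carboxylic acid or an amide, and all of the values here are far too few to support a general rule for the series.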